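The source may hold more compounds than are shown below. What is called first, only, known or untested is meant among the compounds shown, and "the series" means these compounds.

Measured in an ADME assay on Caco-2 cells (Homo sapiens) for permeability, read by LC-MS, in the apical to basolateral direction, with a stated time of 2 h, tested at 2 uM; on this read-out lower numbers stand for lower permeability and higher numbers for higher permeability:
- compound 1 `CC[C@@H](Nc1c(C#N)c(-c2ccc(-c3cccc(C)c3F)cc2)nc2cnccc12)C(N)=O`: 47 nm/s
- compound 2 `CCOc1ccccc1-c1ccc(-c2nc3cnccc3c(N[C@H](CC)C(N)=O)c2C#N)cc1`: 151 nm/s

Of these two, compound 2 holds the higher number at 151 nm/s, and its gap to compound 1 lies beyond the usual scatter. Compound 3 `CC[C@@H](Nc1c(C#N)c(-c2ccc(-c3ccc(Cl)cc3)cc2)nc2cnccc12)C(N)=O` is the next to be measured. The change is 4-chlorophenyl in place of 2-ethoxyphenyl on an aromatic carbon, which puts 4-chlorophenyl in place of 2-ethoxyphenyl on an aromatic carbon. Within the data shown here, only one measured step bears on this: a 3.2-fold higher number from compound 1 to compound 2 (0.51 log units; beyond the scatter), where 2-ethoxyphenyl replaced 2-fluoro-3-methylphenyl. Among the measured compounds shown here, with 2-ethoxyphenyl leaving again, a modest drop of similar size is expected, although no measured compound carries 4-chlorophenyl, so the expectation is loose. The expected change in this assay is a 2.0-fold lower number from compound 2 to compound 3 (0.30 log units; within the scatter). The estimated value for compound 3 is 75 nm/s, with an expected range from 30 nm/s to 170 nm/s.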

Compound 3, apparent permeability: 29 nm/s
The estimate for compound 3 lay 2.6-fold (0.41 log units) above the measured number, and the stated range ends above it.
By their numbers in this assay, from the lowest: compounds 3 and 1 (each within the scatter of the next); then compound 2.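

In this assay, among these compounds, the aromatic carbon that carries the outer aryl group now responds to a second exchange, as 4-chlorophenyl in place of 2-ethoxyphenyl gives a 5.2-fold lower number from compound 2 to compound 3 (0.72 log units; beyond the scatter) and 2-ethoxyphenyl is the only one of the three groups whose compound stands apart from both others. The two groups without oxygen cannot be separated on this read-out: replacing 2-fluoro-3-methylphenyl with 4-chlorophenyl gives a 1.6-fold lower number from compound 1 to compound 3 (0.21 log units; within the scatter) and so leaves compound 1 and compound 3 together. Nothing measured here accounts for why compound 2 stands apart.

The compounds shown leave open whether the higher number of compound 2 follows the oxygen of its 2-ethoxyphenyl group, the ethyl chain on that oxygen or the place of that group on the ring. On these data alone, how a 4-ethoxyphenyl group, a 2-methoxyphenyl group or a carboxylic acid would read at this position also remains open.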